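The source may report more compounds than this note shows. Statements on the series, on what has been measured and on what is new or still open speak of the compounds shown alone.

Compound 1 `Nc1nc(SCc2ccccc2)nc2c1nc(O)n2Cc1ccccc1` gives 0.1 uM in a functional assay (spleen, spleen) for activation, with Mus musculus as the target; on this read-out lower numbers stand for an effect already at smaller amounts and higher numbers for an effect only at larger amounts of compound.
Compound 2 `CSc1nc2c(N)ncnc2n1Cc1ccccc1` gives only a limit of the assay in this assay, > 10 uM.
Compound 3 `COc1ccc(Cn2c(O)nc3c(N)ncnc32)cc1` gives 10 uM in this assay.

Of the two numbers measured, compound 1 holds the lower one, and its gap to compound 3 lies well beyond the scatter. Compound 2 stands at a limit of > 10 uM in this assay, at which 1 of the 3 values shown sits, and adds no number. Compound 4 `CCCC[S+]([O-])c1nc(N)c2nc(O)n(Cc3ccccc3)c2n1` has not yet been measured; it differs from compound 1 by a group of 6 heavy atoms (4 carbon, 1 oxygen, 1 sulfur; no ring) in place of a group of 8 heavy atoms (7 carbon, 1 sulfur; one six-membered aromatic ring of carbon only), on an aromatic carbon. Within the data shown here, no measured pair shows this change, so the expected step from compound 1 to compound 4 rests only on the size of the change: a loss expected in this assay, a 10-fold higher number from compound 1 to compound 4 (1.00 log units; beyond the scatter). Compound 4 is therefore estimated at 1 uM, within 0.1 uM to 10 uM.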

Compound 4, minimum effective concentration: 0.01 uM
Beside the measured number, compound 4's estimate is 100-fold (2.00 log units) above it; the measured number lies below the stated range.
By their numbers in this assay, from the lowest: compound 4; then compound 1; then compound 3.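

In this assay, the aromatic carbon between two ring nitrogen atoms tolerates the loss of benzylsulfanyl, and the group without a ring gives a 10-fold lower number from compound 1 to compound 4 (1.00 log units; beyond the scatter). The six-membered aromatic ring of benzylsulfanyl is therefore not required at this place for an effect at small amounts on the core of compound 1. Nothing measured here accounts for this step. The compounds shown leave open whether the oxygen on sulfur or the open chain carries the step. A butylsulfanyl group or an amine at this place would test that.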